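Methoxy in place of methyl in compound 4

The source may report more compounds than this note shows. Statements on the series, on what has been measured and on what is new or still open speak of the compounds shown alone.

Values so far in a functional assay on RS4-11 cells (Homo sapiens) for inhibition, read by CCK-8 assay, with a stated time of 48 h, tested at 20 uM; a lower number here means less inhibition of growth, a higher number more inhibition of growth at the concentration tested
Compound 1 `COc1ccc(Cc2nnc(NC(=O)/C(C#N)=C/c3ccccc3OS(=O)(=O)c3ccc(OC)cc3)s2)cc1` gives 78%
Compound 2 `COc1ccc(S(=O)(=O)Oc2ccccc2/C=C(\C#N)C(=O)Nc2nnc(Cc3ccccc3)s2)cc1` gives 78%
Compound 3 `Cc1ccc(S(=O)(=O)Oc2ccccc2/C=C(\C#N)C(=O)Nc2nnc(Cc3ccc(F)cc3)s2)cc1` gives 72%

In this assay compound 3 gives 72% and lies within the scatter of both compound 1 and compound 2, so the three numbers cannot be told apart. Compound 4 `COc1ccc(S(=O)(=O)Oc2ccccc2/C=C(\C#N)C(=O)Nc2nnc(Cc3ccc(F)cc3)s2)cc1` differs from compound 3 in one place, with methoxy in place of methyl on an aromatic carbon, para to a large group. The 4-methylphenyl of compound 3 thus becomes 4-methoxyphenyl methoxy in place of methyl on an aromatic carbon in the sulfonyl group.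

For the measured compounds named here, no measured step makes this exact exchange. Going by the values given here, the one single-place step available is no change at the digits printed from compound 1 to compound 2 (within the scatter) and it puts hydrogen in place of methoxy on an aromatic carbon. That methoxy is not the one entering here, so the step bears on the question only loosely. Compound 1 and compound 2 both carry the (4-methoxyphenyl)sulfonyl group that compound 4 gains, and compound 2 gives 78% in this assay with it, which allows at most a slight upward lean. The estimated step is a number 3 percentage points higher from compound 3 to compound 4 (within the scatter) and none beyond the scatter is expected. For compound 4 the expected value is 75% with an estimated range from 64% to 86% in this measurement.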

Compound 4, percent growth inhibition at one concentration: 76%
Estimate against measurement, compound 4: 1 percentage points below, within the range that was stated.
By their numbers in this assay, from the lowest: compounds 3, 4, 1 and 2 (each within the scatter of the next).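

In this assay, the exchange of methyl for methoxy in the (4-methylphenyl)sulfonyl group can now be read directly (a number 4 percentage points higher from compound 3 to compound 4 (within the scatter)), and on this single-concentration read-out the 4-methylphenyl and 4-methoxyphenyl groups cannot be told apart at this place. Compound 4 also links this position to the other end of the molecule: with the (4-methoxyphenyl)sulfonyl group held fixed, fluoro in place of hydrogen (a number 2 percentage points lower from compound 2 to compound 4 (within the scatter)) and fluoro in place of methoxy (a number 2 percentage points lower from compound 1 to compound 4 (within the scatter)) both stay within the scatter, so neither exchange separates these compounds here. Nothing measured alongside these numbers offers an explanation for why these exchanges leave the growth inhibition so flat.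

The compounds shown leave open whether a group of another kind on the same aromatic carbon, such as an amine, a carboxylic acid or a longer chain like butoxy, would move the number beyond the scatter. They also leave open whether compounds that cannot be told apart at this one concentration would still differ across a full range of concentrations.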